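The source may report more compounds than this note shows. Statements on the series, on what has been measured and on what is new or still open speak of the compounds shown alone.

Of the compounds shown here, three have been measured in a functional assay on A498 cells (Homo sapiens) for inhibition, read by sulforhodamine B assay, with a stated time of 48 h; a higher number here means that more compound is tolerated, a lower number that less compound is tolerated. Compound 1 `COc1cc(-c2nn(-c3cccc(NC(=O)Nc4ccc(Cl)c(Cl)c4)c3)cc2-c2ccncc2)ccc1Cl` reaches only a limit of this assay, > 50000 nM. Compound 2 `O=C(Nc1cccc(-n2cc(-c3ccncc3)c(-c3ccc(Cl)c(O)c3)n2)c1)Nc1ccc(Cl)c(Cl)c1` likewise reaches only a limit, > 32500 nM. Compound 3 `COc1cc(-c2nn(-c3cccc(NC(=O)c4ccccc4)c3)cc2-c2ccncc2)ccc1Cl` also stops at a limit, > 100000 nM. With nothing but limits at hand, the step from compound 1 to compound 2, a hydrogen in place of methyl on an oxygen on an aromatic ring, reads as a step that the two limits leave unreadable from compound 1 to compound 2, and the step from compound 1 to compound 3, phenyl in place of (3,4-dichlorophenyl)amino on a carbonyl carbon, reads as a step that the two limits leave unreadable from compound 1 to compound 3. Compound 2 thus stands at a limit, and the two other values shown are limits as well.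

Compound 4 `O=C(Nc1cccc(-n2cc(-c3ccncc3)c(-c3ccc(Cl)c(O)c3)n2)c1)Nc1ccc(Cl)c(C(F)(F)F)c1` differs from compound 2 by trifluoromethyl in place of chloro on an aromatic carbon, a trifluoromethyl in place of chloro on an aromatic carbon of a six-membered aromatic ring of carbon only, ortho to a chloro group and meta to a large group. Neither measured step touches this position, and neither has a readable size, so no step beyond the scatter can be foreseen. The step from compound 2 to compound 4 is estimated as a step that the limit leaves unreadable from compound 2 to compound 4. Compound 4 is therefore expected to give about 40000 nM, within 15000 nM to 100000 nM, most likely again only as a limit.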

Compound 4, concentration lethal to 50% of the cells: > 32500 nM
Compound 4 gave a limit, no number; the forecaster's own chance of this, stated with the estimate: 80%; the middle value is on the limit's open side.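

Compound 2 and compound 4 both stop at the same limit in this assay, so trifluoromethyl in place of chloro gives no readable step: the limit of > 32500 nM in this assay, at which 2 of the 4 values shown sit.

The compounds shown leave open what concentration of any of them is actually lethal to these cells, and whether any of these changes alters it.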